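Triazole series: amide change at compound 4

A few compounds are considered here, and "the series" means these few. Any claim that something is new, unique, unknown or untested is made for them only; others in the source may bear on it.

Compound 2 `CCc1ccc(Cn2c(CCc3ccccc3)nnc2[C@H](NC(=O)c2ccccn2)c2c[nH]c3ccccc23)cc1` gives 67 nM in an in vitro assay on LLC-PK1 cells for displacement of a labelled ligand from growth hormone secretagogue receptor type 1 (Homo sapiens) (on this read-out lower numbers stand for stronger inhibition and higher numbers for weaker inhibition), the highest of the three numbers measured. Its nearest neighbour is compound 1 `COc1ccc(Cn2c(CCc3ccccc3)nnc2[C@H](NC(=O)c2ccccn2)c2c[nH]c3ccccc23)c(OC)c1`, which gives 1.1 nM, and the step of a 61-fold higher number from compound 1 to compound 2 (1.78 log units; beyond the scatter) is large. Compound 3 `COc1ccc(Cn2c(CCc3ccccc3)nnc2[C@H](NC(=O)c2ccccn2)c2c[nH]c3ccccc23)cc1` gives 0.7 nM, and the step of a 96-fold lower number from compound 2 to compound 3 (1.98 log units; beyond the scatter) is also large, whereas the step of a 1.6-fold lower number from compound 1 to compound 3 (0.20 log units; within the scatter) stays within the scatter. Compound 4 `CCc1ccc(Cn2c(CCc3ccccc3)nnc2[C@H](NC(=O)Cc2cccnc2)c2c[nH]c3ccccc23)cc1` differs from compound 2 by (pyridin-3-yl)methyl in place of pyridin-2-yl on a carbonyl carbon. For the measured compounds named here, none of the measured steps touches this part of the molecule: all three concern the aryl group on the saturated chain carbon bound to the aromatic nitrogen, and the amide was the same in every measured compound. There is therefore no measured basis for a direction, and the expectation is drawn only from compound 2 itself. Compound 4 is estimated at 90 nM, with a range from 20 nM to 500 nM, meaning an expected step of a 1.3-fold higher number from compound 2 to compound 4 (0.13 log units; within the scatter) that is not beyond the scatter.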

Compound 4, half-maximal inhibitory concentration: 480 nM
The estimate for compound 4 lay 5.3-fold (0.73 log units) below the measured number; the measured number falls inside the stated range.
By their numbers in this assay, from the lowest: compounds 3 and 1 (each within the scatter of the next); then compound 2; then compound 4.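

In this assay, the amide is shown for the first time to matter: a 7.2-fold higher number from compound 2 to compound 4 (0.86 log units; beyond the scatter), a modest step but one beyond the scatter, whereas all earlier steps concerned the aryl group on the saturated chain carbon. Replacing pyridin-2-yl on the carbonyl carbon with (pyridin-3-yl)methyl therefore weakens inhibition on the ethyl-bearing compound, so this position does not tolerate the change without loss. No evidence is available to explain this weakening.

The compounds shown leave open whether the loss follows from the changed pyridine attachment or the added carbon, which a (pyridin-2-yl)methyl or a pyridin-3-yl group on the carbonyl carbon could separate. They also leave open whether the same change would weaken inhibition with the methoxy-bearing aryl group of compound 3.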